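From 2,4-difluorobenzyl to 4-fluorobenzyl: one fluoro leaves

The source may hold more compounds than are shown below. What is called first, only, known or untested is meant among the compounds shown, and "the series" means these compounds.

Compound 1 `N#Cc1cc2c(nc1N1CCC(C(=O)NS(=O)(=O)Cc3cccc(F)c3)CC1)COC2=O`: 70500 nM
Compound 2 `N#Cc1cc2c(nc1N1CCC(C(=O)NS(=O)(=O)Cc3ccc(F)cc3F)CC1)COC2=O`: 5200 nM

Going by the values given here, in a functional assay (Platelet, plasma) for inhibition, with Homo sapiens as the target (a lower number here means a stronger inhibitor, a higher number a weaker inhibitor), compound 2 gives 5200 nM, the lower of the two numbers so far, which makes it the stronger inhibitor of the pair. Compound 3 `N#Cc1cc2c(nc1N1CCC(C(=O)NS(=O)(=O)Cc3ccc(F)cc3)CC1)COC2=O` keeps the shared core and differs from compound 2 at a single spot: hydrogen in place of fluoro on an aromatic carbon. In words, this is hydrogen in place of fluoro on an aromatic carbon, turning 2,4-difluorophenyl into 4-fluorophenyl.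

Among the compounds with values here, only one measured step bears on this change: a 14-fold lower number from compound 1 to compound 2 (1.13 log units; beyond the scatter), with 2,4-difluorophenyl in place of 3-fluorophenyl. Within the data shown here, that step is large, but it alters more than one fluoro, so no measured pair isolates the fluoro leaving here. Compound 1, which also carries a single fluoro, as 3-fluorophenyl rather than 4-fluorophenyl, stands at 70500 nM, so a move toward a higher number is expected, though a smaller one than that step. The expected change is a 2.9-fold higher number from compound 2 to compound 3 (0.46 log units; beyond the scatter). Compound 3 is estimated at 15000 nM, with an expected range of 4000 nM to 60000 nM.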

Compound 3, half-maximal inhibitory concentration: 3500 nM
For compound 3 the middle estimate is 4.3-fold (0.63 log units) above the measured one, outside the stated range (below it).
By their numbers in this assay, from the lowest: compounds 3 and 2 (each within the scatter of the next); then compound 1.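

In this assay, removing one fluoro to turn 2,4-difluorophenyl into 4-fluorophenyl gives a 1.5-fold lower number from compound 2 to compound 3 (0.17 log units; within the scatter) and this step lies within the usual scatter, so compound 2 and compound 3 cannot be told apart. At this aromatic carbon, ortho to a large group, fluoro and hydrogen therefore read the same in this measurement. The single-fluoro comparison is far from flat: 4-fluorophenyl in place of 3-fluorophenyl gives a 20-fold lower number from compound 1 to compound 3 (1.30 log units; beyond the scatter) and this step is large and beyond the scatter, so among these three compounds the clear divide runs between compound 1, the only one with 3-fluorophenyl, and the two that carry a fluoro in the 4-fluorophenyl arrangement.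

The compounds shown leave open whether a chloro or a methoxy group on that same aromatic carbon would read like fluoro and hydrogen do, or whether only something this small passes unnoticed. They also leave open what a plain benzyl group, with no fluoro on the ring at all, would give. Nothing available explains these numbers.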